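Tolerated concentration across three amide analogues and one candidate

The source may report more compounds than this note shows. Statements on the series, on what has been measured and on what is new or still open speak of the compounds shown alone.

Measured so far in a toxicity assay on THP-1 cells (Homo sapiens) for inhibition; a higher number here means that more compound is tolerated, a lower number that less compound is tolerated:
Compound 1, `CCCC(=O)Nc1ncc(-c2ccc(OC)cc2)n1C`, gives only a limit, > 100000 nM.
Compound 2, `Cc1ccc(-c2cnc(NC(=O)c3ccc(F)cc3)n2C)cc1`, gives 60000 nM.
Compound 3, `COc1ccc(-c2cnc(NC(=O)c3ccc(F)cc3)[nH]2)cc1`, gives only a limit, > 100000 nM.

For the measured compounds named here, compound 1 sits at the limit of > 100000 nM in this assay, at which 2 of the 3 values shown sit; the number itself is not reached, so no step from it to another compound is measured. Compound 4, `COc1ccc(-c2cnc(NC(=O)c3cccc(C)c3)n2C)cc1`, is not yet measured. It differs from compound 1 by 3-methylphenyl in place of propyl on a carbonyl carbon.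

Expected size of the step in this assay: none beyond the scatter, or at most a modest shift toward less tolerated. Compound 2, also an aryl amide, gives 60000 nM. Compound 3 stays at its limit.

The estimate for compound 4 is 80000 nM, between 30000 nM and 200000 nM, an expected step of an at least 1.2-fold lower number from compound 1 to compound 4 (0.09 log units; that floor lies within the scatter).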

Compound 4, half-maximal cytotoxic concentration: > 100000 nM
Compound 4 ended at the assay's limit; the forecaster's own chance of this, stated with the estimate: 45%; at least 1.2-fold (0.09 log units) between middle value and limit.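

In this assay, for the compounds shown here, compound 1 and compound 4 both give only a limit, so no step between them can be read: the limit of > 100000 nM in this assay, at which 3 of the 4 values shown sit.

Going by these compounds, whether 3-methylphenyl in place of propyl on a carbonyl carbon changes the tolerated concentration at all stays open, since neither compound has a number beyond its limit.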